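Pyridyloxy series: dimethylpyridine variant of compound 2

A few compounds are considered here, and "the series" means these few. Any claim that something is new, unique, unknown or untested is made for them only; others in the source may bear on it.

Compound 1, `COc1cccc(-c2ccn(CCC(C)C)c(=O)c2C#N)c1`: 3170 nM
Compound 2, `CC(C)CCn1ccc(-c2ccc(Oc3cccnc3)cc2)c(C#N)c1=O`: 479 nM

In a functional assay on CHO cells for positive allosteric modulation of metabotropic glutamate receptor 2 (Homo sapiens), read by scintillation counting and GTPgammaS binding, with a stated time of 30 min (a lower number here means that less compound is needed, a higher number that more compound is needed for the effect), compound 2 gives 479 nM, the lowest of the two numbers; compound 1 gives 3170 nM, a gap beyond the scatter. Compound 3, `Cc1ccc(Oc2ccc(-c3ccn(CCC(C)C)c(=O)c3C#N)cc2)c(C)n1`, differs from compound 2 by 2,6-dimethylpyridin-3-yl in place of pyridin-3-yl on an oxygen on an aromatic ring. Among the measured compounds shown here, no measured pair shows this change, so its size is unknown; a step within the scatter, or a small shift in either direction, is the expectation. For compound 3 the estimate is 350 nM, ranging from 120 nM to 1000 nM. The step of a 1.4-fold lower number from compound 2 to compound 3 (0.14 log units; within the scatter) is expected to stay within the scatter.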

Compound 3, half-maximal effective concentration: 100 nM
Beside the measured number, compound 3's estimate is 3.5-fold (0.54 log units) above it; the whole stated range lies above it.
By their numbers in this assay, from the lowest: compound 3; then compound 2; then compound 1.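

In this assay, among the compounds shown here, the change from pyridin-3-yl to 2,6-dimethylpyridin-3-yl on the oxygen gives a 4.8-fold lower number from compound 2 to compound 3 (0.68 log units; beyond the scatter) as the first reading at this place. The ring on the oxygen can therefore carry two added methyl groups while the number falls, and this position responds to substitution on that ring. No measurement at hand explains the step.

Going by these compounds, the two methyl groups enter together, and their separate shares stay open. Also open, on these data alone, is how a methoxy group or a chlorine atom on the same pyridine ring would read.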